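This account rests on a few compounds, and the source may have more. Where it says the series, first, only, none or still open, it means among the compounds named here.

Three compounds have been measured in a functional assay on HT-1080 cells (Homo sapiens) for antiproliferative activity, read by sulforhodamine B assay, with a stated time of 48 h; a lower number here means a stronger inhibitor, a higher number a weaker inhibitor:

compound 1 `CC(C)c1ccccc1OS(=O)(=O)c1ccc(NC(=O)CCl)cc1`: 1000 nM
compound 2 `CC(C)c1ccccc1OS(=O)(=O)c1ccc(NC(=O)CCCCl)cc1`: 3800 nM
compound 3 `O=C(CCCCl)Nc1ccc(S(=O)(=O)Oc2ccccc2I)cc1`: 12000 nM

Compound 2 holds the second highest of these three numbers: compound 1 sits at a lower number and compound 3 at a higher one. Two single changes have been measured. From compound 1 to compound 2 the chain bound to the carbonyl carbon is lengthened, and a 3.8-fold higher number from compound 1 to compound 2 (0.58 log units; beyond the scatter). From compound 2 to compound 3 a group on an aromatic carbon is exchanged, and a 3.2-fold higher number from compound 2 to compound 3 (0.50 log units; beyond the scatter).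

Compound 4 `CC(C)c1ccccc1OS(=O)(=O)c1ccc(NC(=O)NCC2CCCC2)cc1` has not yet been measured. It differs from compound 2 in one place: (cyclopentylmethyl)amino in place of 3-chloropropyl on a carbonyl carbon. Within the data shown here, only the step from compound 1 to compound 2 concerns the same carbonyl carbon, and it was modest. Among the measured compounds shown here, no measured step removes the chlorine-bearing chain or brings in a ring or a hydrogen-bond donor at this position, so the expectation rests on thin ground. A modest move toward a higher number is expected, a 2.1-fold higher number from compound 2 to compound 4 (0.32 log units; beyond the scatter). Compound 4 is therefore estimated at 8000 nM in this assay, with a range from 2000 nM to 30000 nM.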

Compound 4, half-maximal inhibitory concentration: 6000 nM
The estimate for compound 4 lay 1.3-fold (0.12 log units) above the measured number; low and high end bracket the measured number.
By their numbers in this assay, from the lowest: compound 1; then compounds 2, 4 and 3 (each within the scatter of the next, the first and the last beyond it).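

Among these compounds, this carbonyl carbon accepts a very different group than the earlier compounds showed: (cyclopentylmethyl)amino removes the chlorine and brings in a ring and a hydrogen-bond donor, yet the exchange gives (a 1.6-fold higher number from compound 2 to compound 4 (0.20 log units; within the scatter)), so compound 2 and compound 4 cannot be told apart. The chlorine-bearing chain of compound 2 is therefore not needed to reach this level of activity, although the shorter chloromethyl group of compound 1 stays ahead of the new group, with (a 6.0-fold higher number from compound 1 to compound 4 (0.78 log units; beyond the scatter)) separating the two. Nothing available explains either result.

Still open, from the compounds shown here alone, is how a plain methyl group on this carbonyl carbon, carrying no chlorine, would compare with compound 1. An open-chain pentylamino group in place of (cyclopentylmethyl)amino would show whether the ring itself counts.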